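Series notes: configuration change on the cyclohexyl of compound 3

The source may report more compounds than this note shows. Statements on the series, on what has been measured and on what is new or still open speak of the compounds shown alone.

Measured so far in an assay on isolated protein for inhibition of protein kinase C delta type (Homo sapiens), read by TR-FRET, with a stated time of 2 h; on this read-out higher numbers stand for weaker inhibition and lower numbers for stronger inhibition:
compound 1 `N#Cc1cnc(NCc2cnccc2C(F)(F)F)cc1NC[C@H]1C[C@@H](O)C1` gives 4200 nM
compound 2 `N#Cc1cnc(NCc2cnccc2C(F)(F)F)cc1N[C@H]1CC[C@H](O)CC1` gives 6500 nM
compound 3 `CO[C@H]1CC[C@@H](CNc2cc(NCc3cnccc3C(F)(F)F)ncc2C#N)CC1` gives 5000 nM

Compound 3 stands second highest of the three numbers. Its nearest neighbour is compound 1, with a 1.2-fold higher number from compound 1 to compound 3 (0.08 log units; within the scatter); furthest is compound 2, with a 1.3-fold lower number from compound 2 to compound 3 (0.11 log units; within the scatter). Across the whole set, including a 1.5-fold higher number from compound 1 to compound 2 (0.19 log units; within the scatter), every step stays within the scatter, so the three compounds cannot be ordered.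

Compound 4 `CO[C@H]1CC[C@H](CNc2cc(NCc3cnccc3C(F)(F)F)ncc2C#N)CC1` is the next step. Relative to compound 3, (the two compounds have the same atoms and bonds and differ only in configuration as drawn: 2 of 2 stereo elements differ (all stereocentres are inverted: mirror images); a stereocentre at a saturated ring carbon is drawn s in compound 3 and r in compound 4; a stereocentre at a saturated ring carbon is drawn s in compound 3 and r in compound 4). Among the compounds with values here, none of the measured steps touches configuration alone: they all swap one saturated group for another, and each of them lay within the scatter. Within the data shown here, there is therefore no direct precedent, and the only guidance is that the saturated substituent has so far moved the number little. Among the measured compounds shown here, the expectation is a step of no change at the digits printed from compound 3 to compound 4 (within the scatter), that is, nothing beyond the scatter, while allowing wider uncertainty than usual for a change with no analogue in the set. Compound 4 is estimated at 5000 nM, in the range 1500 nM to 16000 nM.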

Compound 4, half-maximal inhibitory concentration: > 10000 nM
Compound 4 ended at the assay's limit; the forecaster's own chance of this, stated with the estimate: 5%; middle value at least 2.0-fold (0.30 log units) away from the limit.
By their numbers in this assay, from the lowest: compounds 1, 3 and 2 (each within the scatter of the next). At a limit, above all of these: compound 4.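

Compound 4 gives no number in this assay, only a limit: the limit of > 10000 nM in this assay, at which 1 of the 4 values shown sits. Within the data shown here, the floor of an at least 2.0-fold higher number from compound 3 to compound 4 (0.30 log units; that floor lies within the scatter) lies within the scatter, so this pair does not fix the size of any effect of configuration on the cyclohexyl, though it is the first pair to isolate that change: the fact that compounds 3 and 4 differ only in the configuration as drawn. Among these compounds, the only step here that clears the scatter is an at least 2.3-fold higher number from compound 1 to compound 4 (0.37 log units; beyond the scatter), whereas the floor of an at least 1.5-fold higher number from compound 2 to compound 4 (0.18 log units; that floor lies within the scatter) stays within it.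

As far as these compounds go, how far compound 4 lies past the limit remains open, and with it the true size of the configuration step. Also open, from the compounds shown here alone, is whether the same configuration change would matter with an amine or a carboxylic acid in place of the methoxy group on the cyclohexyl.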